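This account rests on a few compounds, and the source may have more. Where it says the series, first, only, none or still open, it means among the compounds named here.

Three compounds have been measured in an assay on HEK293 cells for positive allosteric modulation of metabotropic glutamate receptor 2 (Rattus norvegicus), read by thallium flux; on this read-out lower numbers stand for an effect already at smaller amounts and higher numbers for an effect only at larger amounts of compound:

compound 1 `O=C(O)c1cc(-c2cccc(COc3ccc4c(=O)n(C5CCC5)sc4c3)c2)ccc1Cl` gives 580 nM
compound 2 `CC(C)CCn1sc2cc(OCc3cccc(-c4ccc(Cl)c(C(=O)O)c4)c3)ccc2c1=O` gives 650 nM
compound 3 `O=C(O)c1cc(-c2cccc(COc3ccc4c(=O)n(C5CC5)sc4c3)c2)ccc1Cl` gives 130 nM

Compound 3 holds the lowest number of the three; compound 1 lies closest to it and compound 2 furthest, both of them beyond the scatter. The unmeasured compound 4 `CC(C)Cn1sc2cc(OCc3cccc(-c4ccc(Cl)c(C(=O)O)c4)c3)ccc2c1=O` differs from compound 3 in one place: isobutyl in place of cyclopropyl on an aromatic nitrogen.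

Among the compounds with values here, two measured steps bear on this change, since both end in the cyclopropyl of compound 3. Going from cyclobutyl to cyclopropyl gave a 4.5-fold lower number from compound 1 to compound 3 (0.65 log units; beyond the scatter), and going from the open isopentyl chain to cyclopropyl gave a 5.0-fold lower number from compound 2 to compound 3 (0.70 log units; beyond the scatter). The step between the cyclobutyl and isopentyl compounds themselves, a 1.1-fold higher number from compound 1 to compound 2 (0.05 log units; within the scatter), stays within the scatter. The two groups that replaced cyclopropyl thus both carried a higher number of similar size, whether ring or chain. Isobutyl is an open chain of four carbons, so compound 4 is expected to move away from compound 3 by a modest step, a 3.8-fold higher number from compound 3 to compound 4 (0.59 log units; beyond the scatter), toward a higher number in this assay. The estimate for compound 4 is 500 nM, with a range from 200 nM to 1500 nM.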

Compound 4, half-maximal effective concentration: 470 nM
For compound 4 the middle estimate is 1.1-fold (0.03 log units) above the measured one; measured number inside the range.
By their numbers in this assay, from the lowest: compound 3; then compounds 4, 1 and 2 (each within the scatter of the next).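

In this assay isobutyl on the aromatic nitrogen also falls on the far side of cyclopropyl, with a 3.6-fold higher number from compound 3 to compound 4 (0.56 log units; beyond the scatter), so cyclopropyl now stands apart from three other groups at this position instead of two. Isobutyl cannot be told apart from the longer isopentyl chain, with a 1.4-fold lower number from compound 2 to compound 4 (0.14 log units; within the scatter), or from the cyclobutyl ring, with a 1.2-fold lower number from compound 1 to compound 4 (0.09 log units; within the scatter), so among these three groups neither a ring nor the length of the chain separates the numbers. Only cyclopropyl goes against this flat picture, and no supporting data here bear on why this group differs from the others.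

As far as these compounds go, what a smaller group such as methyl or ethyl would give on this nitrogen stays open, as does cyclopropylmethyl, which would show whether the three-membered ring still counts when it is set one carbon further out. Also open is whether cyclopropyl would keep its place among these groups if an amide or a tetrazole took the place of the carboxylic acid on the shared core.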